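Methyl addition on two different rings of a shared scaffold

The source may report more compounds than this note shows. Statements on the series, on what has been measured and on what is new or still open speak of the compounds shown alone.

Compound 1 `O=C(CCSc1ccc2c(/C=C/c3ccccn3)n[nH]c2c1)Nc1cccc(C(F)(F)F)c1` is the reference point of this set. In an ADME assay on BaF3 cells (Mus musculus) for antiproliferative activity, read by CCK-8 assay, with a stated time of 72 h (a lower number here means a stronger inhibitor of growth, a higher number a weaker inhibitor of growth), compound 1 gives 2300 nM. Compound 2 `Cc1ccc(NC(=O)CCSc2ccc3c(/C=C/c4ccccn4)n[nH]c3c2)cc1C(F)(F)F` carries one more carbon; in this assay compound 2 gives 530 nM. The change behind that gap is methyl in place of hydrogen on an aromatic carbon and it produced a 4.3-fold lower number from compound 1 to compound 2 (0.64 log units; beyond the scatter).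

Compound 3 `CN1CCN(Cc2ccc(NC(=O)CCSc3ccc4c(-c5cccnc5)n[nH]c4c3)cc2C(F)(F)F)CC1` belongs to a different core; the difference between the two cores is not broken down here. In this assay compound 3 gives 2650 nM, which sits within the scatter of compound 1 and beyond it from compound 2.

Compound 4 `Cc1ccc(-c2n[nH]c3cc(SCCC(=O)Nc4ccc(CN5CCN(C)CC5)c(C(F)(F)F)c4)ccc23)cn1` has not been measured. Its relation to compound 3 is methyl in place of hydrogen on an aromatic carbon. This is the same kind of change as that from compound 1 to compound 2, but the surroundings differ: there the methyl entered a six-membered aromatic ring of carbon only, ortho to a trifluoromethyl group; here it enters a six-membered aromatic ring with 1 nitrogen, next to the ring nitrogen. Because the earlier step of a 4.3-fold lower number from compound 1 to compound 2 (0.64 log units; beyond the scatter) was modest and the place is not the same, compound 4 is expected to show a smaller step, a 1.8-fold lower number from compound 3 to compound 4 (0.25 log units; within the scatter), with an estimated value of 1500 nM, between 500 nM and 4000 nM.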

Compound 4, concentration for 50% growth inhibition: 1180 nM
Compound 4: the middle estimate sits 1.3-fold (0.10 log units) above what was measured; the measured number falls inside the stated range.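

In this assay, the change from pyridin-3-yl to 6-methylpyridin-3-yl gives a 2.2-fold lower number from compound 3 to compound 4 (0.35 log units; beyond the scatter), so methyl in place of hydrogen on an aromatic carbon again lowers the number on this second core. Set beside the earlier step, the two sizes cannot be told apart: the same change on two cores in this assay, a 4.3-fold lower number (0.64 log units; beyond the scatter) from compound 1 to compound 2 and a 2.2-fold lower number (0.35 log units; beyond the scatter) from compound 3 to compound 4, 1.9-fold (0.29 log units) apart, within the scatter of two such steps. This shows that the direction of the change held in these two pairs, but the methyl sat on a different ring in each, a ring of carbon only in one and a ring with 1 nitrogen in the other, so the pairs do not show that a methyl at one given place carries over between cores, nor why either step occurs.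

The compounds shown leave open whether an ethyl group, a methoxy group or an amine at the place of the new methyl would give a step of the same direction. They also leave open how the methyl would behave on the other ring of each core.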